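From hydroxy to cyano on compound 3

The source may report more compounds than this note shows. Statements on the series, on what has been measured and on what is new or still open speak of the compounds shown alone.

In a functional assay on MDA-MB-231 cells (Homo sapiens) for cytotoxicity, with a stated time of 48 h (a higher number here means a weaker inhibitor, a lower number a stronger inhibitor), compound 3 `Oc1ccc(-c2cncc(-c3cc4ccc(O)cc4[nH]3)n2)cc1` gives 10000 nM. That value lies within the scatter of both other measured compounds: compound 1 `N#Cc1ccc(-c2cncc(-c3cc4ccc(O)cc4[nH]3)c2)cc1` gives 12000 nM and compound 2 `CS(=O)(=O)c1ccc(-c2cncc(-c3cc4ccc(O)cc4[nH]3)c2)cc1` gives 5000 nM.

Compound 4 `N#Cc1ccc(-c2cncc(-c3cc4ccc(O)cc4[nH]3)n2)cc1` has cyano in place of hydroxy on an aromatic carbon, para to a large group: cyano in place of hydroxy on an aromatic carbon. Among the measured compounds shown here, no measured step makes this exchange. For the measured compounds named here, the nearest evidence is the single measured step, a 2.4-fold lower number from compound 1 to compound 2 (0.38 log units; beyond the scatter), which is modest and puts methylsulfonyl in place of cyano, so it involves the entering group but not the leaving one. It gives only a rough idea of how far such an exchange can move the number in this assay. Compound 1, which carries cyano, gives 12000 nM, within the scatter of compound 3. No shift beyond the scatter is therefore expected, and the expected step is a 1.1-fold higher number from compound 3 to compound 4 (0.04 log units; within the scatter). For compound 4 the estimated value is 11000 nM, with an expected range from 4500 nM to 25000 nM.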

Compound 4, half-maximal inhibitory concentration: 6000 nM
Beside the measured number, compound 4's estimate is 1.8-fold (0.26 log units) above it, within the range that was stated.
By their numbers in this assay, from the lowest: compounds 2, 4, 3 and 1 (each within the scatter of the next, the first and the last beyond it).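

In this assay, the exchange of hydroxy for cyano on an aromatic carbon, para to a large group, is read directly as a 1.7-fold lower number from compound 3 to compound 4 (0.22 log units; within the scatter) and stays within the scatter. The earlier compounds shown here offered no step of this exchange, and this one shows that 4-hydroxyphenyl and 4-cyanophenyl are not told apart at this position, even though the hydrogen-bond donor of hydroxy is absent from cyano. Nothing available gives a measured reason for this result.

Going by these compounds, only these two groups can be compared at this position, so it remains open whether an amine, a carboxylic acid or a longer chain there would move the number beyond the scatter. Also open, on these data alone, is whether the step of a 2.4-fold lower number from compound 1 to compound 2 (0.38 log units; beyond the scatter) that puts methylsulfonyl in place of cyano would carry over to the core of compound 4.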